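Methyl to Methoxy: What the Paw Edema Read-out May Show

The compounds below may be only part of what the source reports. "The series", "measured", "known", "first", "only" and "open" are said of these compounds alone.

Going by the values given here, compound 1, `Cc1ccc2[nH]c(-c3cccc(C)n3)nc2c1`, was tested in a functional assay on the whole organism with Rattus norvegicus as the target, read by paw edema, with a stated time of 3 h, at a dose of 100 mg/kg by the oral route (a lower number here means less inhibition, a higher number more inhibition at the dose given (going by the name of the read-out)), and gave 42%, the higher of the two numbers measured so far. Among the compounds with values here, compound 2, `Cc1ccc2[nH]c(-c3ccc(C)c(C)n3)nc2c1`, gave -19% in this assay, and the single measured step, a number 61 percentage points lower from compound 1 to compound 2 (beyond the scatter), shows that adding a methyl on an aromatic carbon removed most of the effect. Compound 3, `COc1cccc(-c2nc3cc(C)ccc3[nH]2)n1`, is not yet measured and differs from compound 1 in one place: methoxy in place of methyl on an aromatic carbon. The measured step adds a group rather than exchanging one and touches a different aromatic carbon, a loose guide at best; it does show that a small change on this ring can move the read-out far. A moderate fall is therefore expected, a number 17 percentage points lower from compound 1 to compound 3 (beyond the scatter), with wide uncertainty. Compound 3 is estimated at 25%, with a likely range from -10% to 55%.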

Compound 3, a percentage reported as inhibition, in the whole organism at one dose (the size of the read-out at that dose, not a potency): 32%
Beside the measured number, compound 3's estimate is 7 percentage points below it, and the stated range covers the measured number.
By their numbers in this assay, from the lowest: compound 2; then compounds 3 and 1 (each within the scatter of the next).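

In this assay, methoxy in place of methyl next to the ring nitrogen gives a number 10 percentage points lower from compound 1 to compound 3 (within the scatter) and so leaves compound 3 and compound 1 indistinguishable, even though this exchange adds an oxygen and a hydrogen-bond acceptor. Going by these compounds alone, the earlier step, a number 61 percentage points lower from compound 1 to compound 2 (beyond the scatter) for a methyl added at a different aromatic carbon, showed only that a small change on this ring can move the read-out far; this result shows that a small change on the same ring need not do so. Nothing available explains why the two steps differ in size.

Going by these compounds, whether an amine, an ethoxy group or a plain hydrogen at this same position would fit the same picture remains open. A single dose and a single time also leave open whether compound 1 and compound 3 would stay this close under other conditions.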